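Replacing the butyl ester in compound 1 with a nitroaryl ester

The source may hold more compounds than are shown below. What is called first, only, known or untested is meant among the compounds shown, and "the series" means these compounds.

Of the compounds shown here, three sharing one bicyclic core have been measured in an ADME assay on a cell-free system (plasma, Homo sapiens) for metabolic stability, with Plasma (Rattus norvegicus) as the target, read by HPLC, at pH 7.4; on this read-out lower numbers stand for a shorter-lived compound and higher numbers for a longer-lived compound. Compound 1 `CCCCC(=O)O[C@@H]1CO[C@H]2[C@@H]1OC[C@@H]2OC(=O)c1ccccc1OC(C)=O` gives 0.0117 h, the lowest of the three numbers, though its neighbours sit close: compound 2 `CC(=O)Oc1ccccc1C(=O)O[C@H]1CO[C@H]2[C@@H]1OC[C@H]2OC(=O)c1ccccc1C` gives 0.0138 h and compound 3 `COc1ccccc1C(=O)O[C@@H]1CO[C@H]2[C@@H]1OC[C@@H]2OC(=O)c1ccccc1OC(C)=O` gives 0.0165 h. The step of a 1.2-fold higher number from compound 1 to compound 2 (0.07 log units; within the scatter) and the step of a 1.4-fold higher number from compound 1 to compound 3 (0.15 log units; within the scatter) both stay within the scatter, as does a 1.2-fold higher number from compound 2 to compound 3 (0.08 log units; within the scatter).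

Compound 4 `CC(=O)Oc1ccccc1C(=O)O[C@H]1CO[C@H]2[C@@H]1OC[C@H]2OC(=O)c1ccc([N+](=O)[O-])cc1` has not yet been measured in this assay. It differs from compound 1 as follows: 4-nitrophenyl in place of butyl on a carbonyl carbon. The two measured steps that bear on this are those from compound 1 to compound 2 and to compound 3, each swapping the same butyl group for a substituted phenyl on the same carbonyl carbon, and neither moved the half-life beyond the scatter.

For compound 4, therefore, no change beyond the scatter is expected; the expected step is a 1.3-fold higher number from compound 1 to compound 4 (0.11 log units; within the scatter). The estimated half-life for compound 4 is 0.015 h, with an expected range from 0.008 h to 0.03 h.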

Compound 4, half-life: 0.0227 h
Beside the measured number, compound 4's estimate is 1.5-fold (0.18 log units) below it; the measured number falls inside the stated range.
By their numbers in this assay, from the lowest: compounds 1, 2, 3 and 4 (each within the scatter of the next).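

Compound 4 extends the earlier picture from 2-methylphenyl and 2-methoxyphenyl to a phenyl ring carrying a nitro group: on this carbonyl carbon, 4-nitrophenyl in place of butyl gives a 1.9-fold higher number from compound 1 to compound 4 (0.29 log units; within the scatter). Set against the other two substituted phenyl groups, the new group gives a 1.4-fold higher number from compound 3 to compound 4 (0.14 log units; within the scatter) and a 1.6-fold higher number from compound 2 to compound 4 (0.22 log units; within the scatter). Butyl and all three substituted phenyl groups therefore cannot be told apart by half-life, even though the entering group here is much larger than butyl.

No measurement available here accounts for this flat result. On these data alone, whether a different kind of group on this carbonyl carbon, such as a phenyl ring bearing a carboxylic acid or a chain ending in an amine, would move the half-life beyond the scatter remains open.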